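Changing the Phenoxy Group: Expected Solubility of Compound 4

This account rests on a few compounds, and the source may have more. Where it says the series, first, only, none or still open, it means among the compounds named here.

In a physicochemical assay for solubility, with a stated time of 18 h, at pH 7.4 (on this read-out lower numbers stand for lower solubility and higher numbers for higher solubility), the three measured compounds give these numbers:
- compound 1 `COc1ccc(F)cc1CNCCCNc1ccnc2cc(C3CCCCC3)ccc12` gives 4200 nM
- compound 2 `COc1ccc(Oc2ccc3c(NCCCNCc4cc(F)ccc4OC)ccnc3c2)cc1` gives 14500 nM
- compound 3 `COc1ccc(F)cc1CNCCCNc1ccnc2cc(Oc3ccc(F)cc3)ccc12` gives 14500 nM

Compound 3 stands level with compound 2 at the digits shown, and the two together hold the highest numbers of the three. Its distance from compound 1 is a 3.5-fold higher number from compound 1 to compound 3 (0.54 log units; beyond the scatter), and the matching move a 3.5-fold higher number from compound 1 to compound 2 (0.54 log units; beyond the scatter) was of the same size.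

Compound 4 `COc1cccc(Oc2ccc3c(NCCCNCc4cc(F)ccc4OC)ccnc3c2)c1` differs from compound 3 in one place: 3-methoxyphenyl in place of 4-fluorophenyl on an oxygen on an aromatic ring. The step that bears most directly on this is no change at the digits printed from compound 2 to compound 3 (within the scatter), where a methoxy and a fluoro on that phenoxy ring gave the same read-out. For the measured compounds named here, the new compound carries a methoxy again, now as 3-methoxyphenyl rather than 4-methoxyphenoxy, and nothing among the measured compounds separates those two arrangements. The expected step is therefore no change at the digits printed from compound 3 to compound 4 (within the scatter), within the scatter. Compound 4 is estimated at 14500 nM, with a range from 7000 nM to 30000 nM.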

Compound 4, solubility: 14500 nM
Estimate against measurement, compound 4: no gap at the digits printed, and the stated range covers the measured number.
By their numbers in this assay, from the lowest: compound 1; then compounds 2, 3 and 4 (each within the scatter of the next).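

In this assay, for the compounds shown here, 3-methoxyphenyl in place of 4-methoxyphenyl on the oxygen gives no change at the digits printed from compound 2 to compound 4 (within the scatter) and so settles what the earlier compounds could not: these two methoxy arrangements read alike here. With 3-methoxyphenyl in place of 4-fluorophenyl there is no change at the digits printed from compound 3 to compound 4 (within the scatter) as well, so three different aryl groups on this oxygen now share one printed number. The gap to the cyclohexyl compound also recurs, with 3-methoxyphenoxy in place of cyclohexyl giving a 3.5-fold higher number from compound 1 to compound 4 (0.54 log units; beyond the scatter) and matching the two earlier moves away from cyclohexyl.

From the compounds shown here alone, whether the number would hold with an amine or a carboxylic acid on the phenoxy ring remains open. Nothing shown here gives a reason for the agreement among these three compounds.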